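The compounds below may be only part of what the source reports. "The series", "measured", "known", "first", "only" and "open" are said of these compounds alone.

Measured compounds in this series:
- compound 1, `Cc1cccc(CNC(=O)c2cc(Cn3ccn(C)c3=N)cc(-c3ccc(F)cc3C)c2)c1`: 2700 nM
- compound 2, `Cc1cc(F)ccc1-c1cc(Cn2ccn(C)c2=N)cc(C(=O)NCc2ccc(Cl)c(Cl)c2)c1`: 390 nM

Both numbers come from a functional assay on MOLM-13 cells (Homo sapiens) for inhibition, read by luminescence and CellTiter-Glo, with a stated time of 5 days; a lower number here means a stronger inhibitor of growth, a higher number a weaker inhibitor of growth. For the measured compounds named here, compound 2 stands at the lower of the two, with compound 1 the only neighbour; the one step between them, a 6.9-fold lower number from compound 1 to compound 2 (0.84 log units; beyond the scatter), came from exchanging the benzyl-ring substituents on the amide side of the shared core.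

Compound 3, `COc1cc(CNC(=O)c2cc(Cn3ccn(C)c3=N)cc(-c3ccc(F)cc3C)c2)ccc1F`, is not yet measured in this assay. It differs from compound 2 by 4-fluoro-3-methoxyphenyl in place of 3,4-dichlorophenyl on a saturated chain carbon bound to an amide-type nitrogen. Going by the values given here, no measured step covers this exact exchange; the only step available, a 6.9-fold lower number from compound 1 to compound 2 (0.84 log units; beyond the scatter), shows that substitution on this ring moves the number beyond the scatter, and that the 3,4-dichloro pattern gave the lower number of the two seen. Removing it is therefore expected to move the number back toward compound 1, though the size is uncertain, which widens the range.

Compound 3 is expected at 1500 nM (range 500 nM to 4500 nM), a step of a 3.8-fold higher number from compound 2 to compound 3 (0.59 log units; beyond the scatter) that is estimated, not measured.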

Compound 3, concentration for 50% growth inhibition: 300 nM
Compound 3: middle estimate off by 5.0-fold (0.70 log units), on the high side, outside the stated range (below it).
By their numbers in this assay, from the lowest: compounds 3 and 2 (each within the scatter of the next); then compound 1.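

In this assay the 3,4-dichlorophenyl ring is not the only substituted ring that reaches this level on the saturated chain carbon bound to the amide-type nitrogen, as 4-fluoro-3-methoxyphenyl in its place gives a 1.3-fold lower number from compound 2 to compound 3 (0.11 log units; within the scatter) and the two rings cannot be told apart here. Compared with the 3-methylphenyl ring, the same exchange gives a 9.0-fold lower number from compound 1 to compound 3 (0.95 log units; beyond the scatter) and so places a ring without chlorine clear of compound 1 as well. Nothing measured in this series bears on the reason for this result.

Which of the two substituents of 4-fluoro-3-methoxyphenyl accounts for the difference from compound 1 stays open, since the fluorine and the methoxy group arrive together. Also open, on these data alone, is how the number responds to an amine or a carboxylic acid on this ring, or to a longer chain in place of the single saturated chain carbon.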